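A few compounds are considered here, and "the series" means these few. Any claim that something is new, unique, unknown or untested is made for them only; others in the source may bear on it.

Measured so far:
- compound 1 `O=C(CCCCc1ccccc1)CC(=O)N[C@H]1CCOC1=O` gives 80000 nM
- compound 2 `O=C(CCCCCCCCCCCc1ccccc1)CC(=O)N[C@H]1CCOC1=O` gives 27000 nM
- compound 3 `O=C(CCCc1ccccc1)N[C@H]1CCOC1=O` gives > 100000 nM (a limit)

In a functional assay on NCI-H630 cells (Homo sapiens) for cytotoxicity, read by sulforhodamine B assay, with a stated time of 5 days (on this read-out lower numbers stand for stronger inhibition and higher numbers for weaker inhibition), compound 1 (80000 nM) has the higher of the two actual numbers. Compound 2 (27000 nM) lies lower, and that gap is beyond the scatter. Compound 3 reads > 100000 nM, which is a limit and not a number.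

Compound 4 `O=C(CCCc1ccccc1)CC(=O)N[C@H]1CCOC1=O` has not yet been measured in this assay. Its difference from compound 1 is phenyl in place of benzyl on a saturated chain carbon, three bonds along the chain from a carbonyl carbon.

For the measured compounds named here, no measured pair shows a step of this kind, so the expectation rests mainly on compound 1 (80000 nM) as the closest reference. Only a small shift towards weaker inhibition is expected, not beyond the scatter. The expected step is a 1.1-fold higher number from compound 1 to compound 4 (0.05 log units; within the scatter). A report as a limit instead of a number remains a real possibility for this compound. For compound 4 the estimated value is 90000 nM, with an expected range from 50000 nM to 160000 nM.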

Compound 4, half-maximal inhibitory concentration: > 100000 nM
Compound 4 was reported as a limit (the forecaster's own chance of this, stated with the estimate: 40%); at least 1.1-fold (0.04 log units) between middle value and limit.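

In this assay, compound 4 gives > 100000 nM, which is a limit of the assay and not a number. For the compounds shown here, this is the first reading of a change on a saturated chain carbon, three bonds along the chain from a carbonyl carbon: phenyl in place of benzyl gives an at least 1.2-fold higher number from compound 1 to compound 4 (0.09 log units; that floor lies within the scatter), so the swap brings no sign of stronger inhibition, yet the floor of that step does not by itself establish a real loss. The step can be read only as a floor, and the series is already crowded against the top of the measurable range: the limit of > 100000 nM in this assay, at which 2 of the 4 values shown sit.

As far as these compounds go, how far compound 4 lies past its limit stays open, so the true size of the step may be small or large. Also open, from the compounds shown here alone, is whether a polar group such as an amine or a carboxylic acid in place of phenyl, on this same chain, would return a measurable number at all in this assay.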